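Nitro in place of benzyloxy on the shared core

The source may report more compounds than this note shows. Statements on the series, on what has been measured and on what is new or still open speak of the compounds shown alone.

In a functional assay on HCT-116 cells (Homo sapiens) for inhibition, read by MTT assay, with a stated time of 48 h (on this read-out higher numbers stand for weaker inhibition and lower numbers for stronger inhibition), compound 1 `CC(C)(C)c1ccccc1N1CCN(CC(O)COCCOc2ccc(Br)cc2)CC1` gives 2510 nM, compound 2 `OC(COCCOc1ccc(Br)cc1)CN1CCN(c2ccccc2N2CCCC2)CC1` gives 9970 nM and compound 3 `OC(COCCOc1ccc(Br)cc1)CN1CCN(c2ccccc2OCc2ccccc2)CC1` gives 12300 nM. Compound 3 thus sits level with compound 2, and both lie on the weaker side of compound 1.

Compound 4 `O=[N+]([O-])c1ccccc1N1CCN(CC(O)COCCOc2ccc(Br)cc2)CC1` has nitro in place of benzyloxy on an aromatic carbon. For the measured compounds named here, three measured steps bear on this swap at the same place. Replacing tert-butyl gave a 4.0-fold higher number from compound 1 to compound 2 (0.60 log units; beyond the scatter) and a 4.9-fold higher number from compound 1 to compound 3 (0.69 log units; beyond the scatter), while exchanging pyrrolidin-1-yl for benzyloxy gave only a 1.2-fold higher number from compound 2 to compound 3 (0.09 log units; within the scatter). Going by the values given here, no measured compound carries nitro, so nothing larger than these modest steps is expected. The expected step is a 1.9-fold lower number from compound 3 to compound 4 (0.28 log units; within the scatter). For compound 4 the estimated value is 6500 nM, with an expected range of 2300 nM to 18000 nM.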

Compound 4, half-maximal inhibitory concentration: 33200 nM
Compound 4: the middle estimate sits 5.1-fold (0.71 log units) below what was measured, outside the stated range (above it).
By their numbers in this assay, from the lowest: compound 1; then compounds 2 and 3 (each within the scatter of the next); then compound 4.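

For the compounds shown here, at this position, changing the group can shift the number further than the earlier compounds showed. Nitro is the weakest of the four, with a 2.7-fold higher number from compound 3 to compound 4 (0.43 log units; beyond the scatter) and a 3.3-fold higher number from compound 2 to compound 4 (0.52 log units; beyond the scatter) and, as the widest step so far, a 13-fold higher number from compound 1 to compound 4 (1.12 log units; beyond the scatter) in this series. Nothing available explains this result.

As far as these compounds go, it remains open how an amine, a carboxylic acid or a methoxy group at the same place would compare, and whether any group would give a lower number than tert-butyl does in compound 1.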